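Chlorine Out, Fluorine In: From Compound 2 to Compound 4

The source may hold more compounds than are shown below. What is called first, only, known or untested is meant among the compounds shown, and "the series" means these compounds.

Of the compounds shown here, three have so far been measured in a functional assay on MDA-MB-231 cells for antagonist activity at C-X-C chemokine receptor type 4 (Homo sapiens), tested at 10 nM; a lower number here means a weaker effect, a higher number a stronger effect of the compound at the concentration tested. Compound 2 `Clc1cccc(NCc2ccc(CNc3ncccn3)cc2)n1` gives 100%, the highest of the three numbers. Compound 1 `Fc1cnc(NCc2ccc(CNc3nccc(C(F)(F)F)n3)cc2)nc1` gives 73%, which sits beyond the scatter under compound 2, and compound 3 `Fc1ccccc1NCc1ccc(CNc2ccccc2F)cc1` gives 32%, the furthest away. Compound 4 `Fc1ccc(NCc2ccc(CNc3ncccn3)cc2)nc1` has not yet been measured. It differs from compound 2 in one place: 5-fluoropyridin-2-yl in place of 6-chloropyridin-2-yl on an amine nitrogen. Among the measured compounds shown here, no two measured compounds differ in a single place, so the size of this step cannot be read from a matched pair. Because compound 2 already gives 100%, the step is expected to be a moderate drop, a number 20 percentage points lower from compound 2 to compound 4 (beyond the scatter). Compound 4 is therefore estimated to give 80%, with a likely range from 55% to 100%.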

Compound 4, a percentage reported as inhibition, at one concentration (the size of the read-out at that concentration, not a potency): 90%
Compound 4: middle estimate off by 10 percentage points, on the low side; the measured number falls inside the stated range.
By their numbers in this assay, from the lowest: compound 3; then compound 1; then compounds 4 and 2 (each within the scatter of the next).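

In this assay, 5-fluoropyridin-2-yl in place of 6-chloropyridin-2-yl on an amine nitrogen gives a number 10 percentage points lower from compound 2 to compound 4 (within the scatter) and is the only single-place step among the compounds shown. This assay therefore does not separate the two groups, which have the same heavy-atom count and differ in their halogen and its ring position. Nothing available explains this outcome.

From the compounds shown here alone, it remains open how an unsubstituted pyridin-2-yl, or a pyridin-2-yl carrying a methoxy or nitrile group, would read at this place. Going by these compounds, the separate contributions of the halogen and its ring position also remain open.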